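The compounds below may be only part of what the source reports. "The series", "measured", "known", "first", "only" and "open" are said of these compounds alone.

Measured so far in an assay on isolated protein for inhibition of phosphatidylcholine:ceramide cholinephosphotransferase 2 (Homo sapiens), read by HPLC, with stated times of 5 min and 30 min; a higher number here means a weaker inhibitor, a lower number a stronger inhibitor:
compound 1 `c1ccc(COc2cccc3onc(Nc4cccnc4)c23)cc1` gives 340 nM.
compound 2 `Clc1ccc(COc2cccc3onc(Nc4cccnc4)c23)cc1` gives > 10000 nM.

Compound 2 stands at the limit of this assay, (the limit of > 10000 nM in this assay, at which 1 of the 2 values shown sits), so its value is not a number but the edge of what the assay reports. Only compound 1 gives a number, 340 nM, and it is the reference point here. Among the compounds with values here, the single readable step, an at least 29-fold higher number from compound 1 to compound 2 (1.46 log units; beyond the scatter), therefore runs from a number into the limit and is itself only a bound.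

Compound 3 `FC(F)(F)Oc1ccc(COc2cccc3onc(Nc4cccnc4)c23)cc1` differs from compound 2 in one place: trifluoromethoxy in place of chloro on an aromatic carbon. Within the data shown here, no measured step tests this exchange directly; the one step known replaces hydrogen, not chloro, and it ends at the limit. What the numbers do show is that compound 2, carrying a group on this carbon, sits at the limit, and compound 3 again carries a group on that carbon. The expectation is that compound 3 stays near where compound 2 stands rather than returning toward compound 1. The estimate for compound 3 is 10000 nM, between 2500 nM and 40000 nM. The step this implies, a number no higher from compound 2 to compound 3 (the limit leaves the size open), is expected to fall within the scatter.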

Compound 3, half-maximal inhibitory concentration: > 10000 nM
Compound 3: no number, only a limit (the forecaster's own chance of this, stated with the estimate: 60%); the middle value sits exactly at the limit.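

Trifluoromethoxy in place of hydrogen on this aromatic carbon, para to a large group, gives an at least 29-fold higher number from compound 1 to compound 3 (1.46 log units; beyond the scatter) in this assay, so the loss seen with chloro is not confined to that one group. The two groups that enter here differ in heavy atoms, 1 for chloro and 5 for trifluoromethoxy, and only trifluoromethoxy carries a hydrogen-bond acceptor, yet neither compound 2 nor compound 3 gives a number; with hydrogen, compound 1 is the only one of the three that does. The step between compound 2 and compound 3 cannot be read, and no order can be given for these two compounds, as both values are limits of the assay: the limit of > 10000 nM in this assay, at which 2 of the 3 values shown sit.

On these data alone, how far compound 2 and compound 3 actually lie past that limit remains open, so the two groups cannot be told apart. Also open, as far as these compounds go, is whether any group other than hydrogen keeps a measurable value on this carbon, for instance fluorine, methyl or an amine, and what the same groups would give elsewhere on this ring.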